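The source may hold more compounds than are shown below. What is called first, only, known or untested is meant among the compounds shown, and "the series" means these compounds.

Compound 1 `C#Cc1sc(-c2ccc(F)cc2)nc1C(=O)OCC` is an ester-bearing compound whose core differs from that of compound 3 `C#Cc1nc2ccccc2n1C`; the difference between the two cores is not broken down here. Compound 2 `C=Cc1nc2ccccc2n1C` shares the core of compound 3. In a functional assay on NCI-H522 cells (Homo sapiens) for cytotoxicity, with a stated time of 3 days (a higher number here means a weaker inhibitor, a lower number a stronger inhibitor), compound 1 gives 3530 nM, compound 2 gives 2340 nM and compound 3 gives 8140 nM. Compound 1 and compound 2 lie within the usual scatter of each other, while compound 3 stands beyond the scatter from both.

For the measured compounds named here, the one change that is measured here, (vinyl in place of ethynyl on an aromatic carbon), gave a 3.5-fold lower number from compound 3 to compound 2 (0.54 log units; beyond the scatter), a modest step on a five-membered aromatic ring with two nitrogen atoms that is part of a fused or bridged system of two rings, between two ring nitrogen atoms and next to the ring atom that bears a methyl group.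

Compound 4 `C=Cc1sc(-c2ccc(F)cc2)nc1C(=O)OCC` has not yet been measured. It differs from compound 1 by vinyl in place of ethynyl on an aromatic carbon, the same kind of change, but the place is another: a five-membered aromatic ring with one nitrogen and one sulfur, next to the ring sulfur and next to the ring atom that bears an ethoxycarbonyl group. Since the surroundings differ, the step is expected to be somewhat smaller than the measured one; the expected step is a 2.4-fold lower number from compound 1 to compound 4 (0.37 log units; beyond the scatter), resting on the step from compound 3 to compound 2. Compound 4 is therefore estimated at 1500 nM, between 600 nM and 4000 nM in this assay .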

Compound 4, half-maximal inhibitory concentration: > 40000 nM
Compound 4: no number, only a limit; the forecaster's own chance of this, stated with the estimate: 0%; middle value at least 26-fold (1.42 log units) away from the limit.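

In this assay compound 4 gives > 40000 nM, which is a limit of the assay and not a number. The same change, vinyl in place of ethynyl on an aromatic carbon, gave an at least 11-fold higher number from compound 1 to compound 4 (1.05 log units; beyond the scatter), a large step that runs opposite to the one seen on the other core, so in this assay the result did not carry from one core to the other, even in direction: the same change on two cores in this assay, a 3.5-fold lower number (0.54 log units; beyond the scatter) from compound 3 to compound 2 and an at least 11-fold higher number (1.05 log units; beyond the scatter) from compound 1 to compound 4, at least 39-fold (1.59 log units) apart, beyond the scatter of two such steps

For the compounds shown here, with only two pairs, this shows that the outcome of the change depends on the core in these compounds, but it does not show which feature of either core is responsible, and the full size of the step on the core of compound 1 remains unknown.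

The compounds shown leave open whether the same loss would appear with a carboxylic acid or an amide in place of the ethoxycarbonyl group. They also leave open how an ethyl group would compare with ethynyl and vinyl on either core, and so whether the result is tied to vinyl itself or to the core that carries it.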